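A few compounds are considered here, and "the series" means these few. Any claim that something is new, unique, unknown or untested is made for them only; others in the source may bear on it.

In an ADME assay on HEK293 cells (Homo sapiens) for cytotoxicity, read by resazurin assay, with a stated time of 48 h (a lower number here means that less compound is tolerated, a higher number that more compound is tolerated), compound 1 `Cc1ccccc1S(=O)(=O)Nc1ccc2oc(-c3ccccc3)nc2c1` gives 57000 nM. Compound 3 `O=S(=O)(Nc1ccc2oc(-c3ccccc3)nc2c1)c1ccc(Cl)c(C(F)(F)F)c1` gives 66000 nM in this assay, and the two numbers sit within the usual scatter of each other, so neither can be set apart from the other. Compound 2 `O=S(=O)(Nc1ccc(-c2nc3ccccc3o2)cc1)c1ccccc1O` gives > 100000 nM in this assay, which is a limit of the assay and not a number; this is the limit of > 100000 nM in this assay, at which 1 of the 3 values shown sits. Compound 1 thus stands among the numbered values, at a level that compound 3 shares.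

Compound 4 `O=S(=O)(Nc1ccc2oc(-c3ccccc3)nc2c1)c1ccc(Cl)s1` has not yet been measured in this assay. It differs from compound 1 in one place (5-chlorothiophen-2-yl in place of 2-methylphenyl on a sulfonyl sulfur). Among the measured compounds shown here, no step between measured compounds separates these two groups, so the data hold no measured guide for this exchange. Compound 1 and compound 3 carry different groups on the sulfonyl sulfur and still give numbers within the scatter of each other, so for compound 4 a step of no more than the scatter is expected in this assay, in either direction. Compound 4 is therefore expected to give 50000 nM, with a range from 20000 nM to 100000 nM. The step this estimate means a 1.1-fold lower number from compound 1 to compound 4 (0.06 log units; within the scatter) is expected to stay within the scatter.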

Compound 4, half-maximal cytotoxic concentration: > 100000 nM
Compound 4 was reported as a limit; the forecaster's own chance of this, stated with the estimate: 25%; at least 2.0-fold (0.30 log units) between middle value and limit.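

In this assay, among the compounds shown here, the exchange of 2-methylphenyl for 5-chlorothiophen-2-yl on a sulfonyl sulfur gives the first step that can be read at this position, and that step is an at least 1.7-fold higher number from compound 1 to compound 4 (0.24 log units; that floor lies within the scatter). For the compounds shown here, it shows that a five-membered aromatic ring with 1 hetero atom can stand on the sulfonyl sulfur without any drop from the number of compound 1, whereas the earlier compounds with a sulfonamide on the same core carried only six-membered aromatic rings of carbon at this place. As far as these compounds go, the reading of compound 4 is a limit of the assay and not a number, so the true size of the step stays unknown, and the reading joins a second compound at the same limit: the limit of > 100000 nM in this assay, at which 2 of the 4 values shown sit.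

The compounds shown leave open whether the chlorine or the five-membered ring itself carries this step, and a plain thiophen-2-yl group would separate the two. Also open, from the compounds shown here alone, is what a longer alkyl chain or an amine on the sulfonyl sulfur would give in this assay, and how far past the limit compound 4 lies.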